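The compounds below may be only part of what the source reports. "The series", "measured", "known", "first", "only" and "open" are said of these compounds alone.

In a functional assay on NCI-H460 cells (Homo sapiens) for inhibition, read by MTT assay, with a stated time of 72 h (a lower number here means a stronger inhibitor, a higher number a weaker inhibitor), the three measured compounds stand as follows.

Compound 1 `N[C@H](CSCC(=O)Nc1c[nH]c(=O)[nH]c1=O)C(=O)O` gives > 100000 nM, a limit of the assay rather than a number.
Compound 2 `Cn1cc(CO)c(N)nc1=O` gives > 100000 nM, again a limit.
Compound 3 `Cc1cc(=O)[nH]c(=O)n1COC(CO)CO` gives > 100000 nM, likewise a limit.

Compound 3 therefore sits where every measured compound sits: at the limit of > 100000 nM in this assay, at which 3 of the 3 values shown sit. No measured value has yet separated any of these compounds from the others, so no step between measured compounds can be read out, and the place of compound 3 is known only as this common limit.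

Compound 4 `O=c1ccn(COC(CO)CO)c(=O)[nH]1` is the next structure. It differs from compound 3 by hydrogen in place of methyl on an aromatic carbon. Going by the values given here, no measured pair shows the effect of such a change in this assay, and the only anchor is that compound 3 itself reports a limit. The expected step from compound 3 to compound 4, a number no higher from compound 3 to compound 4 (the limit leaves the size open), is therefore none beyond the scatter. Compound 4 is estimated at 100000 nM, between 30000 nM and 300000 nM, most likely reported again as a limit.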

Compound 4, half-maximal inhibitory concentration: > 100000 nM
Compound 4 gave a limit, no number; the forecaster's own chance of this, stated with the estimate: 85%; the middle value lies on the limit itself.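

In this assay, compound 3 and compound 4 both stand at a limit of the assay, so no step can be read between them: the limit of > 100000 nM in this assay, at which 4 of the 4 values shown sit.

The compounds shown leave open what size of effect, if any, hydrogen in place of methyl on an aromatic carbon has in this assay.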